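Compound 1 to compound 4: a change on the amine chain

A few compounds are considered here, and "the series" means these few. Any claim that something is new, unique, unknown or untested is made for them only; others in the source may bear on it.

Values in a functional assay for inhibition, with Rattus norvegicus as the target; on this read-out lower numbers stand for an effect already at smaller amounts and higher numbers for an effect only at larger amounts of compound:
compound 1 `CC[C@H](CC1CCCCC1)NCc1ccc(C(=O)N[C@@H](CCSC)C(=O)O)c(-c2ccccc2C)c1`: > 1000 nM (a limit)
compound 2 `CSCC[C@H](NC(=O)c1ccc(CN(CCC2CCCCC2)C(C)=O)cc1-c1ccccc1C)C(=O)O`: > 1000 nM (a limit)
compound 3 `CSCC[C@H](NC(=O)c1ccc(CN(C)CCC2CCCCC2)cc1-c1ccccc1C)C(=O)O`: 12 nM

Compound 1 gives only a limit, and it stands at the limit of > 1000 nM in this assay, at which 2 of the 3 values shown sit.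

Compound 4 `CSCC[C@H](NC(=O)c1ccc(CN[C@H](CSC(C)(C)C)CC2CCCCC2)cc1-c1ccccc1C)C(=O)O` differs from it as follows: (tert-butyl)sulfanyl in place of methyl on a saturated chain carbon, two bonds along the chain from an amine nitrogen. This places (tert-butyl)sulfanyl in place of methyl on a saturated chain carbon, two bonds along the chain from an amine nitrogen.

Among the measured compounds shown here, no measured step makes this exact change. Replacing the whole amino group gave an at least 83-fold lower number from compound 1 to compound 3 (1.92 log units; beyond the scatter), so large movement is possible here, while a step that the two limits leave unreadable from compound 1 to compound 2 gives no size.

A moderate move towards lower numbers is therefore expected, with wide uncertainty. The estimated step in this assay is an at least 3.3-fold lower number from compound 1 to compound 4 (0.52 log units; beyond the scatter).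

Compound 4 is expected at 300 nM, with an estimated range of 30 nM to 3000 nM.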

Compound 4, half-maximal effective concentration: 2.8 nM
The estimate for compound 4 lay 110-fold (2.03 log units) above the measured number, outside the stated range (below it).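

Placing (tert-butyl)sulfanyl in place of methyl on a saturated chain carbon, two bonds along the chain from an amine nitrogen, gives an at least 350-fold lower number from compound 1 to compound 4 (2.55 log units; beyond the scatter) in this assay. The earlier readable steps replaced the whole amino group, whereas here the amine stays and a change further out on the chain is enough for a large move. The size of this step has only a lower bound, since compound 1 stands at a limit: the limit of > 1000 nM in this assay, at which 2 of the 4 values shown sit.

From the compounds shown here alone, it remains open whether the sulfur or the tert-butyl group carries the step. A methylsulfanyl or a neopentyl group at this position would separate the two.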